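The source may hold more compounds than are shown below. What is called first, only, known or untested is meant among the compounds shown, and "the series" means these compounds.

Compound 3, `O=C(/C=C/c1ccccc1)c1ccc(N2CCN(S(=O)(=O)c3ccc4ccccc4c3)CC2)cc1`, gives 35% in a functional assay on the whole organism (strain Kunming) for inhibition, with Mus musculus as the target, with a stated time of 1 h, at a dose of 40 mg/kg by the oral route (a lower number here means less inhibition, a higher number more inhibition at the dose given (going by the name of the read-out)), the second highest of the three numbers measured. Compound 2, `O=C(/C=C/c1ccccc1)c1ccc(N2CCN(S(=O)(=O)c3ccc(Cl)cc3)CC2)cc1`, gives 46.8%, and compound 1, `O=C(/C=C/c1ccccc1)c1ccc(N2CCN(c3ccc(Cl)c(Cl)c3)CC2)cc1`, gives 13.4%. The step of a number 33.4 percentage points higher from compound 1 to compound 2 (beyond the scatter) shows the sulfonyl compounds sitting well above compound 1, while the step of a number 11.8 percentage points lower from compound 2 to compound 3 (beyond the scatter) shows that enlarging the aryl group on the sulfonyl sulfur cost some inhibition. Compound 4, `O=C(/C=C/c1ccccc1)c1ccc(N2CCN(S(=O)(=O)c3ccccc3)CC2)cc1`, differs from compound 3 by phenyl in place of naphthalen-2-yl on a sulfonyl sulfur. Since this shrinks the aryl group again, a modest rise in this assay toward compound 2 is expected, roughly undoing the step from compound 2 to compound 3. For compound 4 the expected result is 42%, with a range from 28% to 56%, corresponding to an expected step of a number 7 percentage points higher from compound 3 to compound 4 (within the scatter).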

Compound 4, a percentage reported as inhibition, in the whole organism at one dose (the size of the read-out at that dose, not a potency): 30%
Estimate against measurement, compound 4: 12 percentage points above; the measured number falls inside the stated range.
By their numbers in this assay, from the lowest: compound 1; then compounds 4 and 3 (each within the scatter of the next); then compound 2.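

In this assay, the step of a number 5 percentage points lower from compound 3 to compound 4 (within the scatter) shows that phenyl and naphthalen-2-yl on a sulfonyl sulfur cannot be told apart, so aryl size alone does not explain the earlier drop. Instead, the step of a number 16.8 percentage points lower from compound 2 to compound 4 (beyond the scatter) shows that the chloro of compound 2 matters, as hydrogen there gives a clear loss. The step of a number 16.6 percentage points higher from compound 1 to compound 4 (beyond the scatter) shows that a sulfonyl compound without chloro still stands clear of compound 1.

As far as these compounds go, whether fluoro, bromo or methoxy in place of that chloro would hold the higher number remains open. No available evidence bears on why these steps arise.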